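From 2,5-difluorophenyl to phenyl on the shared core

The source may hold more compounds than are shown below. What is called first, only, known or untested is meant among the compounds shown, and "the series" means these compounds.

In a functional assay on SGC-7901 cells (Homo sapiens) for antiproliferative activity, read by MTT assay, with a stated time of 72 h (a lower number here means a stronger inhibitor, a higher number a weaker inhibitor), compound 1 `COc1cc(-n2cnc3ccc(-c4ccc(C(C)=O)cc4)cc32)cc(OC)c1OC` gives 450 nM, and compound 2 `COc1cc(-n2cnc3ccc(-c4cc(F)ccc4F)cc32)cc(OC)c1OC` gives 6590 nM, the higher number of the two. Compound 3 `COc1cc(-n2cnc3ccc(-c4ccccc4)cc32)cc(OC)c1OC` differs from compound 2 by phenyl in place of 2,5-difluorophenyl on an aromatic carbon, with phenyl in place of 2,5-difluorophenyl on an aromatic carbon. Among the compounds with values here, only one measured step bears on this, and only indirectly: a 15-fold higher number from compound 1 to compound 2 (1.17 log units; beyond the scatter), a large step beyond the scatter, in which 2,5-difluorophenyl replaces 4-acetylphenyl at the same place. No measurement isolates the loss of the fluorines. A moderate move toward a lower number is expected, estimated as a 3.3-fold lower number from compound 2 to compound 3 (0.52 log units; beyond the scatter). For compound 3 the estimated value is 2000 nM, with an expected range of 600 nM to 6500 nM.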

Compound 3, half-maximal inhibitory concentration: 290 nM
For compound 3 the middle estimate is 6.9-fold (0.84 log units) above the measured one, outside the stated range (below it).
By their numbers in this assay, from the lowest: compounds 3 and 1 (each within the scatter of the next); then compound 2.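

In this assay, the two fluorines turn out to be costly at this position, with a 23-fold lower number from compound 2 to compound 3 (1.36 log units; beyond the scatter), so the high number of compound 2 goes with the 2,5-difluorophenyl group rather than with the loss of acetyl alone. The acetyl itself is not required, since hydrogen in its place gives a 1.6-fold lower number from compound 1 to compound 3 (0.19 log units; within the scatter). Nothing available explains why the fluorines have this effect. Which of the two fluorines carries the loss remains open, as does whether a single fluorine would carry it at all. On these data alone, how an amine or a carboxylic acid in place of acetyl would compare also stays open.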